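This account rests on a few compounds, and the source may have more. Where it says the series, first, only, none or still open, it means among the compounds named here.

Measured in a functional assay on MCF7 cells (Homo sapiens) for antiproliferative activity, read by MTT assay, with a stated time of 48 h; a higher number here means a weaker inhibitor, a lower number a stronger inhibitor:
- Compound 1 `C#CC(C)OC(=O)c1ccc(C(CC)(CC)c2ccc(OCCC(O)(CC)CC)c(C)c2)n1CC`: > 50000 nM
- Compound 2 `CCn1c(C(=O)Nc2ccc(OC(F)(F)F)cc2)ccc1C(CC)(CC)c1ccc(OCCC(O)(CC)CC)c(C)c1`: > 50000 nM

Both entries are limits of the assay and not numbers. Compound 2 thus stands at the limit of > 50000 nM in this assay, at which 2 of the 2 values shown sit, and no numerical value is available for either compound. Compound 3 `CCn1c(C(=O)N(C)CC(=O)O)ccc1C(CC)(CC)c1ccc(OCCC(O)(CC)CC)c(C)c1` keeps the core of compound 2 but carries (carboxymethyl)(methyl)amino in place of (4-(trifluoromethoxy)phenyl)amino on a carbonyl carbon.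

One measured change bears on this, since it falls on a carbonyl carbon too. There, (4-(trifluoromethoxy)phenyl)amino took the place of (1-methylprop-2-yn-1-yl)oxy, giving a step that the two limits leave unreadable from compound 1 to compound 2. That step offers no size to carry over, and it gives no direction either. Among the compounds with values here, with a step that the two limits leave unreadable from compound 1 to compound 2 as the only guide, no change beyond the scatter is expected in this assay, in either direction. The expected step is a number no higher from compound 2 to compound 3 (the limit leaves the size open). A reading at the same limit is the most likely outcome for compound 3. The estimated value for compound 3 is 50000 nM, with an expected range from 20000 nM to 80000 nM.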

Compound 3, half-maximal inhibitory concentration: 79 nM
Estimate against measurement, compound 3: 630-fold (2.80 log units) above, outside the stated range (below it).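

In this assay, the carbonyl carbon of the shared core now proves to be a place where the attached group decides the outcome: (carboxymethyl)(methyl)amino in place of (4-(trifluoromethoxy)phenyl)amino gives an at least 630-fold lower number from compound 2 to compound 3 (2.80 log units; beyond the scatter), and the same group in place of (1-methylprop-2-yn-1-yl)oxy gives an at least 630-fold lower number from compound 1 to compound 3 (2.80 log units; beyond the scatter). The earlier step between compound 1 and compound 2 could not be read, since both values are limits of the assay, so only compound 3 shows that this position can carry a measurable effect on the cells. Both new steps start from a limit, which leaves their full size open: the limit of > 50000 nM in this assay, at which 2 of the 3 values shown sit.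

The change removes an aromatic ring and brings in a carboxylic acid and a methyl on the amide nitrogen all at once, so the compounds shown do not tell which of these accounts for the step. A methyl ester of compound 3, a dimethylamino group or a longer chain ending in the carboxylic acid, each on the same carbonyl carbon, would begin to separate these parts.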